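Three cytotoxicity limits and a fourth compound to test

The compounds below may be only part of what the source reports. "The series", "measured", "known", "first", "only" and "open" are said of these compounds alone.

Compound 1 `O=C(Nc1ccc(Cl)c(-c2nc3ccccc3s2)c1)c1cc([N+](=O)[O-])ccc1Cl`: in an ADME assay on BJ cells (Homo sapiens) for cytotoxicity, with a stated time of 72 h (a lower number here means that less compound is needed, a higher number that more compound is needed for the effect), compound 1 gives only a limit, > 25000 nM.
Compound 2 `COc1ccc(-c2nc3ccccc3s2)cc1NC(=O)c1cc([N+](=O)[O-])ccc1Cl`: in this assay compound 2 gives only a limit, > 25000 nM.
Compound 3 `COc1ccc(NC(=O)c2cc([N+](=O)[O-])ccc2Cl)cc1-c1nc2ccccc2s1`: in this assay compound 3 gives only a limit, > 25000 nM.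

Compounds 2 and 3 are built from the same atoms joined differently; the difference between the two cores is not broken down here. From compound 3 to compound 1 the change is chloro in place of methoxy on an aromatic carbon, and the step it made is a step that the two limits leave unreadable from compound 3 to compound 1, because both ends sit at the limit of > 25000 nM in this assay, at which 3 of the 3 values shown sit.

Compound 4 `O=C(Nc1cc(-c2nc3ccccc3s2)ccc1Cl)c1cc([N+](=O)[O-])ccc1Cl` has not been measured. It differs from compound 2 by chloro in place of methoxy on an aromatic carbon. The surroundings differ: in the measured pair the chloro sits ortho to a 1,3-benzothiazol-2-yl group and para to a large group, whereas in compound 4 it sits ortho to a large group and para to the 1,3-benzothiazol-2-yl group, so this is the same kind of change, not the same change.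

In this assay the expected step is a step that the limit leaves unreadable from compound 2 to compound 4, set beside a step that the two limits leave unreadable from compound 3 to compound 1, resting on the fact that compound 3 and compound 1 both sit at the limit of > 25000 nM in this assay, at which 3 of the 3 values shown sit. Compound 4 is estimated at 40000 nM, expected between 15000 nM and 120000 nM.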

Compound 4, half-maximal effective concentration: > 25000 nM
Compound 4 ended at the assay's limit; the forecaster's own chance of this, stated with the estimate: 85%; the middle value does not contradict the limit.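

No new step can be read between compound 2 and compound 4, because in this assay both stop at the same limit: the limit of > 25000 nM in this assay, at which 4 of the 4 values shown sit.

The compounds shown leave open whether chloro in place of methoxy changes the half-maximal effective concentration at all in this assay, and how far any of the four compounds lies past the limit.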